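The compounds below may be only part of what the source reports. "The series", "measured", "known", "first", "only" and "open" are said of these compounds alone.

Working notes on the series. In a functional assay on MCF7 cells (Homo sapiens) for cytotoxicity, read by MTT assay, with a stated time of 72 h (on this read-out higher numbers stand for weaker inhibition and lower numbers for stronger inhibition), compound 1 (`COC(=O)c1sc2cc(OC)ccc2c1Nc1cc(OC)c(OC)c(OC)c1`) gives 0.7 nM and compound 2 (`COC(=O)c1sc2nc(C)ccc2c1Nc1cc(OC)c(OC)c(OC)c1`) gives 0.53 nM. For the measured compounds named here, these two values lie within the scatter of each other, so compound 1 stands level with the only other measured compound.

Compound 3 (`COC(=O)c1sc2ccccc2c1Nc1cc(OC)c(OC)c(OC)c1`) has hydrogen in place of methoxy on an aromatic carbon of compound 1: hydrogen in place of methoxy on an aromatic carbon. Going by the values given here, no measured pair isolates this change, so the expectation rests on the structural change alone. In this assay, a step beyond the scatter is expected, towards a higher number and so weaker inhibition, though its size is poorly constrained. The estimated step is a 43-fold higher number from compound 1 to compound 3 (1.63 log units; beyond the scatter). For compound 3 the expected value is 30 nM, with an estimated range from 2 nM to 400 nM.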

Compound 3, half-maximal inhibitory concentration: 795 nM
Compound 3: middle estimate off by 27-fold (1.42 log units), on the low side; the measured number lies above the stated range.
By their numbers in this assay, from the lowest: compounds 2 and 1 (each within the scatter of the next); then compound 3.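

In this assay, this position on the six-membered aromatic ring proves far from indifferent: hydrogen in place of methoxy gives a 1100-fold higher number from compound 1 to compound 3 (3.06 log units; beyond the scatter). This is the only pair shown that differs in one place, and it ties a large loss of inhibition to this single change on the shared core. No measurement shown here accounts for the size of this step.

Only methoxy and hydrogen are shown at this position, so it stays open whether a hydroxyl, an ethoxy, a fluorine or an amine would stay close to compound 1 at 0.7 nM or fall towards compound 3 at 795 nM. As far as these compounds go, it also stays open whether the same change would give a step of similar size on a core carrying other groups.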